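A few compounds are considered here, and "the series" means these few. Any claim that something is new, unique, unknown or untested is made for them only; others in the source may bear on it.

So far, two compounds have been measured in a functional assay on A549 cells (Homo sapiens) for inhibition, read by MTT assay, with a stated time of 72 h (on this read-out lower numbers stand for stronger inhibition and higher numbers for weaker inhibition), and have structures that differ in more than one place. Compound 1 `COc1ccc(-c2cc(=O)oc3ccccc23)cn1` gives 41000 nM and compound 2 `COc1ccc2oc(=O)cc(-c3cccc(C#N)c3)c2c1` gives 13000 nM in this test. Compound 2 therefore holds the lower of the two numbers, and the gap between them lies beyond the usual scatter.

Compound 3 `COc1ccc2oc(=O)cc(-c3cccc(C(N)=O)c3)c2c1` keeps the structure of compound 2 except for one swap, with carbamoyl in place of cyano on an aromatic carbon as the counted difference. Among the measured compounds shown here, no measured pair shows what this swap does, so the expectation stays close to compound 2 at 13000 nM and no step beyond the scatter is expected. The estimated step is a 1.5-fold higher number from compound 2 to compound 3 (0.19 log units; within the scatter) and its direction is uncertain. For compound 3 the estimated value is 20000 nM with an expected range from 7000 nM to 60000 nM in this assay.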

Compound 3, half-maximal inhibitory concentration in the A549 assay: 34000 nM
The estimate for compound 3 lay 1.7-fold (0.23 log units) below the measured number, and the stated range covers the measured number.
By their numbers in the A549 assay, from the lowest: compound 2; then compounds 3 and 1 (each within the scatter of the next).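

Among the compounds shown here, replacing cyano with carbamoyl gives the first change that can be read on its own, because compounds 2 and 3 differ in only one place. In the A549 assay, the swap gives a 2.6-fold higher number from compound 2 to compound 3 (0.42 log units; beyond the scatter), so inhibition at this aromatic carbon depends on which group sits there, and the cyano compound is the stronger of this pair. In a physicochemical assay for solubility, in phosphate buffer, with a stated time of 2 h, at pH 7.4 (a higher number here means a more soluble compound, a lower number a less soluble compound), compound 2 gives 40000 nM and compound 3 gives 120000 nM in this test. The same swap that weakens inhibition goes with higher solubility in the physicochemical assay: the measured solubility of compound 2, 40000 nM, and of compound 3, 120000 nM, a 3.0-fold higher number (0.48 log units; beyond the scatter)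

A single pair cannot show whether inhibition and solubility would pull apart in this way for other groups at this position. As far as these compounds go, whether an amine, a carboxylic acid or a methyl ester on the same carbon could keep the inhibition of compound 2 while reaching the solubility of compound 3 remains open.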